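A Nitro Group Enters the Phenyl Ring of Compound 1

The source may report more compounds than this note shows. Statements on the series, on what has been measured and on what is new or still open speak of the compounds shown alone.

Compound 1 `CSc1nc(NCCCCNc2ccnc3cc(Cl)ccc23)c(C#N)c(-c2ccccc2)n1` was tested in an ADME assay on MDCK cells (Canis lupus familiaris) for cytotoxicity, read by microscopy (on this read-out higher numbers stand for lower toxicity in this test and lower numbers for higher toxicity in this test), where compound 1 gives 20000 nM, the higher of the two plain numbers recorded here. Compound 2 `CSc1nc(OCCCNc2ccnc3cc(Cl)ccc23)c(C#N)c(-c2ccccc2)n1` gives 4000 nM, a value below that of compound 1 by a gap beyond the scatter. Compound 3 `CSc1nc(-c2ccccc2)c(C#N)c(N2CCN(c3ccnc4cc(Cl)ccc34)CC2)n1` reaches only a limit of the assay, > 100000 nM, and not a number (the limit of > 100000 nM in this assay, at which 1 of the 3 values shown sits). Compound 4 `CSc1nc(NCCCCNc2ccnc3cc(Cl)ccc23)c(C#N)c(-c2cccc([N+](=O)[O-])c2)n1` is the untested compound; compared with compound 1 it carries nitro in place of hydrogen on an aromatic carbon. Going by the values given here, no pair of measured compounds shows this change, so the step from compound 1 to compound 4 is estimated as no change at the digits printed from compound 1 to compound 4 (within the scatter), expected to stay within the scatter in either direction. Compound 4 is therefore expected to give 20000 nM, estimated between 7000 nM and 60000 nM.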

Compound 4, minimum cytotoxic concentration: 20000 nM
For compound 4 middle estimate and measured number coincide at the digits printed; measured number inside the range.
By their numbers in this assay, from the lowest: compound 2; then compounds 1 and 4 (each within the scatter of the next). At a limit, above all of these: compound 3.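

In this assay, a change on the phenyl ring itself can now be read, and it shows no change at the digits printed from compound 1 to compound 4 (within the scatter). Going by these compounds alone, the earlier compounds all carry an unsubstituted phenyl ring, so only this pair shows that nitro in place of hydrogen here, meta to a large group, gives no shift beyond the scatter. Nothing in the data shown accounts for this result. Going by these compounds, whether an amine or a carboxylic acid on the same ring carbon would give the same reading stays open. So does whether nitro would do the same on compound 2.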